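A few compounds are considered here, and "the series" means these few. Any claim that something is new, unique, unknown or untested is made for them only; others in the source may bear on it.

Compound 1 `Cc1ccc(C(=O)N/N=C/C2=C(Cl)c3ccccc3CCC2)cc1` gives 300 nM in a functional assay on HeLa cells (Homo sapiens) for inhibition, read by sulforhodamine B assay, with a stated time of 48 h; a lower number here means a stronger inhibitor of growth, a higher number a weaker inhibitor of growth. Compound 2 `Nc1ccccc1C(=O)N/N=C/C1=C(Cl)c2ccccc2CCC1` sits at a limit of this assay, > 100000 nM. Compound 3 `O=C(N/N=C/C1=C(Cl)c2ccccc2CCC1)c1cccnc1` gives 7500 nM.

Of the two numbers shown, compound 3 carries the higher one; the step of a 25-fold higher number from compound 1 to compound 3 (1.40 log units; beyond the scatter) separates it from compound 1, while compound 2 stands at the limit (the limit of > 100000 nM in this assay, at which 1 of the 3 values shown sits). Compound 4 `O=C(N/N=C/C1=C(Cl)c2ccccc2CCC1)c1cccc(I)c1` differs from compound 3 by 3-iodophenyl in place of pyridin-3-yl on a carbonyl carbon. Going by the values given here, two measured steps bear on exchanges of the aryl group on this carbonyl carbon, a 25-fold higher number from compound 1 to compound 3 (1.40 log units; beyond the scatter) and an at least 13-fold lower number from compound 2 to compound 3 (1.12 log units; beyond the scatter), both large. Compound 4 brings back a ring of carbon only, and because of the step of a 25-fold higher number from compound 1 to compound 3 (1.40 log units; beyond the scatter) a lower number in this assay is expected; for compound 4 the expected step is a 13-fold lower number from compound 3 to compound 4 (1.10 log units; beyond the scatter). Compound 4 is estimated at 600 nM, between 120 nM and 3000 nM.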

Compound 4, concentration for 50% growth inhibition: 6300 nM
Compound 4: the middle estimate sits 11-fold (1.02 log units) below what was measured; measured number above the stated range.
By their numbers in this assay, from the lowest: compound 1; then compounds 4 and 3 (each within the scatter of the next). At a limit, above all of these: compound 2.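

In this assay, a ring of carbon only on this carbonyl carbon is not enough to reach the number of compound 1: 3-iodophenyl in place of pyridin-3-yl gives a 1.2-fold lower number from compound 3 to compound 4 (0.08 log units; within the scatter), while 3-iodophenyl in place of 4-methylphenyl gives a 21-fold higher number from compound 1 to compound 4 (1.32 log units; beyond the scatter). Against 2-aminophenyl, 3-iodophenyl gives an at least 15-fold lower number from compound 2 to compound 4 (1.20 log units; beyond the scatter). The value of compound 2 is a limit: the limit of > 100000 nM in this assay, at which 1 of the 4 values shown sits.

The compounds shown leave open how a plain phenyl ring would stand on this carbonyl carbon. They also leave open the effect of a methoxy group or a chlorine on that ring.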